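This account rests on a few compounds, and the source may have more. Where it says the series, first, only, none or still open, it means among the compounds named here.

Measured compounds:

Compound 1 `c1ccc(-c2cn3ccnc3c(-c3ccc4ncn(C5CCCCC5)c4c3)n2)cc1`; in a functional assay on SF-268 cells (Homo sapiens) for inhibition, read by sulforhodamine B assay, with a stated time of 48 h, tested at 10 uM (a lower number here means less inhibition, a higher number more inhibition at the concentration tested (going by the name of the read-out)), compound 1 gives 21.7%.
Compound 2 `c1ccc2c(-c3cn4ccnc4c(-c4ccc5ncn(C6CCCCC6)c5c4)n3)cccc2c1`; compound 2 gives 7.84%.
Compound 3 `Fc1ccc(-c2cn3ccnc3c(-c3ccc4ncn(C5CCCCC5)c4c3)n2)cc1`; compound 3 gives 10.7%.

Among these three, compound 1 stands highest, and its steps to both other compounds lie beyond the scatter: a number 13.9 percentage points lower from compound 1 to compound 2 (beyond the scatter) and a number 11 percentage points lower from compound 1 to compound 3 (beyond the scatter). Compounds 2 and 3 lie within the scatter of each other.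

The next compound, compound 4 `Brc1ccc(-c2cn3ccnc3c(-c3ccc4ncn(C5CCCCC5)c4c3)n2)cc1`, is reached from compound 1 by a single change: bromo in place of hydrogen on an aromatic carbon. Cut one bond further out, this reads phenyl to 4-bromophenyl.

Within the data shown here, the step that bears most directly on this is the one to compound 3, where a different halogen enters at the same place: a number 11 percentage points lower from compound 1 to compound 3 (beyond the scatter). Among the measured compounds shown here, only one such step is known, so its size is the best guide. On that basis a modest fall is expected, a number 9.7 percentage points lower from compound 1 to compound 4 (within the scatter).

Compound 4 is therefore estimated at 12%, with a likely range from 2% to 25%.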

Compound 4, a percentage reported as inhibition, at one concentration (the size of the read-out at that concentration, not a potency): 15.5%
Estimate against measurement, compound 4: 3.5 percentage points below; low and high end bracket the measured number.
By their numbers in this assay, from the lowest: compounds 2, 3, 4 and 1 (each within the scatter of the next, the first and the last beyond it).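

In this assay, bromo on the phenyl ring gives a number 6.2 percentage points lower from compound 1 to compound 4 (within the scatter) and so cannot be told apart from hydrogen at this place, unlike fluoro, which gives a number 11 percentage points lower from compound 1 to compound 3 (beyond the scatter) and lies beyond the scatter. The two halogens cannot be told apart from each other either, given a number 4.8 percentage points higher from compound 3 to compound 4 (within the scatter) in this assay, and the same holds for naphthalen-1-yl and 4-bromophenyl, given a number 7.7 percentage points higher from compound 2 to compound 4 (within the scatter) here. Compound 4 therefore overlaps all three earlier compounds, so these numbers set no clear order among hydrogen, bromo, fluoro and naphthalen-1-yl at this place.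

Going by these compounds, whether an amine, a carboxylic acid or a methoxy group here would stand clearly above compound 1 remains open. Nothing available gives a reason for any of these numbers.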